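Cytotoxicity notes on the hydroxypyrrolidine replacement

This account rests on a few compounds, and the source may have more. Where it says the series, first, only, none or still open, it means among the compounds named here.

Compound 1 `COc1ccc(/C=C\c2cc(OC)c(OC)c(OC)c2)cc1OCc1ccc(CNC(C)(C)C(=O)O)cc1` stands at a limit in an ADME assay on HEK293 cells (Homo sapiens) for cytotoxicity, read by CCK-8 assay, with a stated time of 48 h; on this read-out higher numbers stand for weaker inhibition and lower numbers for stronger inhibition: compound 1 gives > 50000 nM, a limit of the assay rather than a number. Compound 2 `COc1ccc(/C=C\c2cc(OC)c(OC)c(OC)c2)cc1OCc1ccc(CN[C@H](C(=O)O)[C@H](C)O)cc1` likewise gives > 50000 nM, again a limit. Compound 3 `COc1ccc(/C=C\c2cc(OC)c(OC)c(OC)c2)cc1OCc1ccc(CO)cc1` gives 37000 nM. The steps of an at least 1.3-fold lower number from compound 1 to compound 3 (0.13 log units; that floor lies within the scatter) and an at least 1.3-fold lower number from compound 2 to compound 3 (0.13 log units; that floor lies within the scatter) lie within the scatter, and a step that the two limits leave unreadable from compound 1 to compound 2 cannot be read, since both values sit at the limit of > 50000 nM in this assay, at which 2 of the 3 values shown sit.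

Compound 4 `COc1ccc(/C=C\c2cc(OC)c(OC)c(OC)c2)cc1OCc1ccc(CN2CC[C@@H](O)C2)cc1` is not yet measured; it differs from compound 1 by 3-hydroxypyrrolidin-1-yl in place of (1-carboxy-1-methylethyl)amino on a saturated chain carbon bound to an aromatic carbon. Among the compounds with values here, no measured step exchanges the group on the saturated chain carbon bound to an aromatic carbon for a ring. The nearest comparison, compound 1 against compound 3, shows only that removing the (1-carboxy-1-methylethyl)amino group leaves the number within the scatter of the limit. In this assay compound 4 is therefore expected to remain near the limit, estimated at 45000 nM with a range of 15000 nM to 50000 nM. The expected step is an at least 1.1-fold lower number from compound 1 to compound 4 (0.04 log units; that floor lies within the scatter), not beyond the scatter.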

Compound 4, half-maximal inhibitory concentration: > 50000 nM
Compound 4 ended at the assay's limit; the forecaster's own chance of this, stated with the estimate: 55%; middle value at least 1.1-fold (0.04 log units) away from the limit.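

In this assay compound 4 gives > 50000 nM, which is a limit of the assay and not a number. This adds a ring to the groups tested on the saturated chain carbon bound to an aromatic carbon: 3-hydroxypyrrolidin-1-yl carries no carboxy group, yet compound 4 still reaches the limit, as compound 1 and compound 2 do with their carboxy-bearing amino groups. The step of an at least 1.3-fold higher number from compound 3 to compound 4 (0.13 log units; that floor lies within the scatter) gives only a floor within the scatter, and the steps from compound 1 and compound 2 to compound 4 cannot be read, as all three compounds sit at the limit: the limit of > 50000 nM in this assay, at which 3 of the 4 values shown sit.

From the compounds shown here alone, whether a piperazine or a morpholine on the same carbon would give a readable number remains open. So does whether the opposite configuration of the 3-hydroxy stereocentre would change the reading.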